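Naphthalene for tert-butylphenyl on the indole sulfonyl

The source may hold more compounds than are shown below. What is called first, only, known or untested is meant among the compounds shown, and "the series" means these compounds.

Going by the values given here, compound 1 `CC(C)(C)c1ccc(S(=O)(=O)n2cc(/C=C/C(=O)c3ccncc3)c3ccccc32)cc1` is one of two compounds measured in a functional assay on HepG2 cells (Homo sapiens) for antiproliferative activity, read by MTT assay, with a stated time of 48 h (on this read-out lower numbers stand for stronger inhibition and higher numbers for weaker inhibition), where compound 1 gives 27000 nM; the step of a 1.3-fold higher number from compound 1 to compound 2 (0.11 log units; within the scatter) places compound 2 `O=C(/C=C/c1cn(S(=O)(=O)c2ccc(Cl)cc2)c2ccccc12)c1ccncc1`, at 35100 nM, within the scatter of compound 1. Compound 3 `O=C(/C=C/c1cn(S(=O)(=O)c2cccc3ccccc23)c2ccccc12)c1ccncc1` is unmeasured and differs from compound 1 by naphthalen-1-yl in place of 4-(tert-butyl)phenyl on a sulfonyl sulfur. Among the compounds with values here, the only measured step also swaps the group on the sulfonyl sulfur and moved nothing beyond scatter, so no step beyond the scatter is expected in this assay either way. Compound 3 is therefore estimated at 30000 nM, between 12000 nM and 75000 nM, a step of a 1.1-fold higher number from compound 1 to compound 3 (0.05 log units; within the scatter).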

Compound 3, half-maximal inhibitory concentration: 62900 nM
Compound 3: the middle estimate sits 2.1-fold (0.32 log units) below what was measured; the measured number falls inside the stated range.
By their numbers in this assay, from the lowest: compounds 1, 2 and 3 (each within the scatter of the next, the first and the last beyond it).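

In this assay the group on a sulfonyl sulfur can now move the number beyond the scatter: the change gives a 2.3-fold higher number from compound 1 to compound 3 (0.37 log units; beyond the scatter) as a modest step, with the leaving and entering groups equal in their count of heavy atoms, and a second six-membered aromatic ring entering. Set against 4-chlorophenyl, naphthalen-1-yl gives a 1.8-fold higher number from compound 2 to compound 3 (0.25 log units; within the scatter) and so only one of the two new steps clears the scatter. Nothing available here speaks to the reason for this. Still open, as far as these compounds go, is whether a 4-methoxyphenyl group or a plain methyl on the sulfonyl sulfur would bring the number lower than in compound 1.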